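The compounds below may be only part of what the source reports. "The series", "measured", "known", "first", "only" and "open" are said of these compounds alone.

Among the measured compounds shown here, in a functional assay on Ehrlich cells (Mus musculus) for cytotoxicity, tested at 25 ug/mL (a higher number here means a stronger effect of the compound at the concentration tested, a lower number a weaker effect), compound 1 `COc1cc(N2C(N)=C(C#N)C(c3ccccc3O)C3=C2CC(C)(C)CC3=O)cc(OC)c1OC` gives 0%, while compound 2 `COc1cc(N2C(N)=C(C#N)C(c3ccc(OC)c4ccccc34)C3=C2CC(C)(C)CC3=O)cc(OC)c1OC` gives 30%, the higher of the two numbers measured so far. For the measured compounds named here, the only measured step, a number 30 percentage points higher from compound 1 to compound 2 (beyond the scatter), put 4-methoxynaphthalen-1-yl in place of 2-hydroxyphenyl. Compound 3 `COc1cc(N2C(N)=C(C#N)C(c3c(O)ccc4ccccc34)C3=C2CC(C)(C)CC3=O)cc(OC)c1OC` differs from compound 2 by 2-hydroxynaphthalen-1-yl in place of 4-methoxynaphthalen-1-yl on a saturated ring carbon, so the two-ring group remains while the hydroxyl of compound 1 returns. That single step bears on the change only in part, and its two ingredients pull against each other here, so a modest fall is expected, about a number 15 percentage points lower from compound 2 to compound 3 (beyond the scatter). Compound 3 is therefore estimated at 15%, within a range from 0% to 35%.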

Compound 3, a percentage reported as activity, at one concentration (the size of the read-out at that concentration, not a potency): 10%
For compound 3 the middle estimate is 5 percentage points above the measured one, and the stated range covers the measured number.
By their numbers in this assay, from the lowest: compounds 1 and 3 (each within the scatter of the next); then compound 2.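

In this assay the two-ring group alone does not hold the effect on this saturated ring carbon: 2-hydroxynaphthalen-1-yl in place of 4-methoxynaphthalen-1-yl gives a number 20 percentage points lower from compound 2 to compound 3 (beyond the scatter) in this one pair. Set against 2-hydroxyphenyl, the same group gives a number 10 percentage points higher from compound 1 to compound 3 (within the scatter) and so no readable gain from the second aromatic ring. Nothing measured here explains these numbers.

The hydroxyl and methoxy groups also differ in where they sit, so the compounds shown cannot separate the group from its location. As far as these compounds go, how 2-methoxynaphthalen-1-yl, 4-hydroxynaphthalen-1-yl or an amine on the naphthalene would read stays open.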